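Swapping the Aryl Group on a Urea Nitrogen

The compounds below may be only part of what the source reports. "The series", "measured", "known", "first", "only" and "open" are said of these compounds alone.

Compound 1, `COc1ccccc1NC(=O)N[C@@H]1C2CCN(CC2)[C@@H]1Cc1cccnc1`, and compound 2, `O=C(Nc1cccc(F)c1)N[C@@H]1C2CCN(CC2)[C@@H]1Cc1cccnc1`, share one core and differ only in the ring attached to an amide-type nitrogen. In an assay on a protein complex for binding affinity to Neuronal acetylcholine receptor; alpha4/beta2 (Homo sapiens) (on this read-out higher numbers stand for weaker inhibition and lower numbers for stronger inhibition), compound 1 gives > 10000 nM, which is a limit of the assay rather than a measured number. In this assay compound 2 likewise gives > 10000 nM, again a limit and not a number. The step that the two limits leave unreadable from compound 1 to compound 2 therefore cannot be read, because of the limit of > 10000 nM in this assay, at which 2 of the 2 values shown sit. Compound 2 thus stands at the limit of this assay, with no number of its own.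

Compound 3, `CN(C)c1ccc(NC(=O)N[C@@H]2C3CCN(CC3)[C@@H]2Cc2cccnc2)cc1`, is not yet measured. The change from compound 2 is 4-(dimethylamino)phenyl in place of 3-fluorophenyl on an amide-type nitrogen. For the measured compounds named here, the only measured step has no readable size, so no measured step bears on this change with a usable size, and nothing shows whether a swap of the ring on this nitrogen moves the number in either direction. Compound 3 is therefore expected at 15000 nM, within 2000 nM to 100000 nM. The step that the limit leaves unreadable from compound 2 to compound 3 is expected to stay within the scatter, with a further limit the most likely outcome.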

Compound 3, inhibition constant: > 10000 nM
Compound 3: only a limit was reported; the forecaster's own chance of this, stated with the estimate: 75%; the middle value lies beyond the limit too.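

In this assay compound 3 gives > 10000 nM, which is again a limit of the assay and not a number. The steps from compound 3 to compound 1 and compound 2 therefore cannot be read, because all three share one limit: the limit of > 10000 nM in this assay, at which 3 of the 3 values shown sit. The compounds shown leave open whether any ring on this nitrogen would give a measurable number.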